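The source may hold more compounds than are shown below. What is called first, only, known or untested is meant among the compounds shown, and "the series" means these compounds.

Compounds measured in a physicochemical assay for lipophilicity, in phosphate buffer, measured as octanol-water partition, with a stated time of 24 h; a lower number here means a more polar compound, a higher number a more lipophilic compound: compound 1 `S=C(N/N=C/c1ccc(Oc2ccc(Br)cc2)cc1)Nc1ccccc1` gives 5.62; compound 2 `S=C(N/N=C/c1ccc(Oc2ccccc2)cc1)Nc1ccc(Br)cc1` gives 6.38; compound 3 `S=C(N/N=C/c1ccc(Oc2ccc3ccccc3c2)cc1)Nc1ccc(Br)cc1` gives 6.93.

Compound 3 stands highest of the three, with compound 2 nearest and compound 1 furthest. Compound 4 `S=C(N/N=C/c1ccc(Oc2ccc(Br)cc2)cc1)Nc1ccc(Br)cc1` differs from compound 3 by 4-bromophenyl in place of naphthalen-2-yl on an oxygen on an aromatic ring. Going by the values given here, the one step that bears on this is a number 0.55 log units higher from compound 2 to compound 3 (beyond the scatter), which goes the other way here. Among the compounds with values here, no step shows the effect of the bromine alone; compound 1 and compound 2 carry it in different places and differ between themselves. Going back from naphthalen-2-yl to a phenyl ring is expected to lower this assay, the added bromine to raise it, so a step of a number 0.03 log units lower from compound 3 to compound 4 (within the scatter) is expected, not beyond the scatter. Compound 4 is estimated at 6.9, range 6.4 to 7.4.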

Compound 4, partition coefficient: 6.53
For compound 4 the middle estimate is 0.37 log units above the measured one; measured number inside the range.
By their numbers in this assay, from the lowest: compound 1; then compounds 2 and 4 (each within the scatter of the next); then compound 3.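

In this assay 4-bromophenyl on the oxygen does not reach the level of naphthalen-2-yl (a number 0.40 log units lower from compound 3 to compound 4 (beyond the scatter)). Bromo in place of hydrogen on an aromatic carbon gives two different readings depending on where it is placed, one (a number 0.15 log units higher from compound 2 to compound 4 (within the scatter)) and the other (a number 0.91 log units higher from compound 1 to compound 4 (beyond the scatter)), so the size of this change is not the same at both sites. Nothing available explains that difference. On these data alone, whether an amine or a carboxylic acid on the ring attached to the oxygen would move this assay well below the values seen so far remains open.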